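The source may report more compounds than this note shows. Statements on the series, on what has been measured and on what is new or still open speak of the compounds shown alone.

Two thiosemicarbazones that share one core have been measured in a functional assay on HeLa cells (Homo sapiens) for antiproliferative activity, read by sulforhodamine B assay, with a stated time of 72 h; a lower number here means a stronger inhibitor, a higher number a weaker inhibitor. Compound 1 `CN(C)C(=S)N/N=C/c1ccc2ccccc2n1` gives 90 nM, while compound 2 `NC(=S)N/N=C/c1ccc2ccccc2n1` gives 960 nM. Among the measured compounds shown here, the one measured step between them, an 11-fold higher number from compound 1 to compound 2 (1.03 log units; beyond the scatter), concerns the substituent on the thiocarbonyl nitrogen; on that basis compound 2 stands highest of the two numbers, with compound 1 its only neighbour.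

Compound 3 `S=C(N/N=C/c1ccc2ccccc2n1)Nc1ccc(Br)cc1` is the next member, and it differs from compound 2 by 4-bromophenyl in place of hydrogen on an amide-type nitrogen. For the measured compounds named here, no measured pair carries this exact change, but the step of an 11-fold higher number from compound 1 to compound 2 (1.03 log units; beyond the scatter) shows that what sits on this nitrogen moves the number a great deal in this assay, and the substituted nitrogen of compound 1 gave the lower number. By that account a step in the lowering direction, beyond the scatter, is expected, so that the estimated step is a 9.6-fold lower number from compound 2 to compound 3 (0.98 log units; beyond the scatter). Compound 3 is accordingly expected to give about 100 nM, with a range from 25 nM to 400 nM.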

Compound 3, half-maximal inhibitory concentration: 56800 nM
For compound 3 the middle estimate is 570-fold (2.75 log units) below the measured one; the whole stated range lies below it.
By their numbers in this assay, from the lowest: compound 1; then compound 2; then compound 3.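

The step of a 59-fold higher number from compound 2 to compound 3 (1.77 log units; beyond the scatter) shows that in this assay a substituent on this amide-type nitrogen does not by itself lower the number: the direction depends on which group enters. Set beside an 11-fold higher number from compound 1 to compound 2 (1.03 log units; beyond the scatter), in which the amino group of compound 2 gave the higher number, the result shows that dimethylamino and 4-bromophenyl push the number in opposite directions relative to compound 2, and that the rise on entry of 4-bromophenyl is the larger of the two steps as printed. Nothing available here explains why this change raises the number so strongly.

The compounds shown leave open whether the rise belongs to the phenyl ring itself or to its bromine, a question that plain phenyl or 4-methoxyphenyl on the same nitrogen would address. They also leave open where the turn from lowering to raising lies, for instance with a single methyl, a longer chain such as n-butyl, or a cyclic amine such as morpholine in place of dimethylamino.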